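A Longer Selenium Chain on a Potent Compound

The compounds below may be only part of what the source reports. "The series", "measured", "known", "first", "only" and "open" are said of these compounds alone.

Measured in a functional assay on HCT-116 cells (Homo sapiens) for inhibition, read by MTT assay, with a stated time of 48 h; on this read-out lower numbers stand for stronger inhibition and higher numbers for weaker inhibition:
Compound 1 `COc1ccc(N(C)c2nc(C)nc3ccccc23)cc1C(=O)OCC[Se]C#N`: 951 nM
Compound 2 `COc1ccc(N(C)c2nc(C)nc3ccccc23)cc1[Se]C`: 28 nM

Compound 2 has the lower of the two numbers. Compound 3 `COc1ccc(N(C)c2nc(C)nc3ccccc23)cc1OCC[Se]C#N` differs from it in one place: a group of 6 heavy atoms (3 carbon, 1 nitrogen, 1 oxygen, 1 selenium; no ring) in place of a group of 2 heavy atoms (1 carbon, 1 selenium; no ring), on an aromatic carbon. For the measured compounds named here, only one measured step bears on this change, and it is large: a 34-fold lower number from compound 1 to compound 2 (1.53 log units; beyond the scatter). There, a big group gave way to a small one. Compound 3 reverses that direction, so a higher number is expected in this assay. Going by the values given here, its group is not the one in compound 1, so the rise is expected to be smaller. The estimate is a 7.1-fold higher number from compound 2 to compound 3 (0.85 log units; beyond the scatter). For compound 3, the estimated value is 200 nM, with an expected range of 40 nM to 900 nM.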

Compound 3, half-maximal inhibitory concentration: 18 nM
Compound 3: middle estimate off by 11-fold (1.05 log units), on the high side; measured number below the stated range.
By their numbers in this assay, from the lowest: compounds 3 and 2 (each within the scatter of the next); then compound 1.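

In this assay, a much longer group at this aromatic carbon costs nothing measurable: a 1.6-fold lower number from compound 2 to compound 3 (0.19 log units; within the scatter) leaves the two compounds level, so chain size alone does not set the number here. The step of a 53-fold lower number from compound 1 to compound 3 (1.72 log units; beyond the scatter) ties the weak result of compound 1 to its particular chain, which holds a carbonyl, and not to a long selenium chain as such. Nothing shown explains either step. As far as these compounds go, whether a longer chain, or an amine in place of the nitrile, would stay in this range remains open. So does the part played by the selenium, which a sulfur atom in its place would address.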